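The compounds below may be only part of what the source reports. "The series", "measured", "known", "first", "only" and "open" are said of these compounds alone.

Compound 1 `CCN(CC)CCCOc1cc2ncnc(Nc3ccc(C#N)cc3)c2cc1OC` is the point of departure. In a functional assay on A549 cells (Homo sapiens) for antiproliferative activity, read by MTT assay, with a stated time of 72 h (a lower number here means a stronger inhibitor, a higher number a weaker inhibitor), compound 1 gives 50600 nM, the highest of the two plain numbers available here. Its nearest neighbour is compound 2 `COc1cc2c(Nc3ccc(C#N)cc3)ncnc2cc1OCCCN1CCC(C)CC1`, which in this assay gives 32300 nM, so that there is a 1.6-fold lower number from compound 1 to compound 2 (0.19 log units; within the scatter). Compound 3 `COc1cc2c(Nc3ccc(C#N)cc3)ncnc2cc1OCCCN1CCCCC1CCO` reaches only a limit in this assay, namely > 100000 nM. From that follows an at least 1.9-fold higher number from compound 1 to compound 3 (0.29 log units; that floor lies within the scatter), and likewise an at least 3.0-fold higher number from compound 2 to compound 3 (0.49 log units; beyond the scatter). The step to compound 4 `COc1cc2c(Nc3ccc(C#N)cc3)ncnc2cc1OCCCN1CCC(N(C)C)CC1` alters the same place: 4-(dimethylamino)piperidin-1-yl in place of diethylamino on a saturated chain carbon, three bonds along the chain from an oxygen on an aromatic ring. The two measured steps at this place show that a six-membered ring in place of diethylamino can leave the number where it is, as with compound 2, or carry it to the limit, as with compound 3. Compound 4 is therefore expected to show no step beyond the scatter, so that a 1.1-fold lower number from compound 1 to compound 4 (0.05 log units; within the scatter). For compound 4 in this assay the estimate is 45000 nM, within a range from 15000 nM to 130000 nM.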

Compound 4, half-maximal inhibitory concentration: 42400 nM
Beside the measured number, compound 4's estimate is 1.1-fold (0.03 log units) above it, within the range that was stated.
By their numbers in this assay, from the lowest: compounds 2, 4 and 1 (each within the scatter of the next). At a limit, above all of these: compound 3.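

Compound 4 shows that this place on the chain accepts 4-(dimethylamino)piperidin-1-yl, a larger group with a second nitrogen, without a step beyond the scatter in this assay: there is a 1.2-fold lower number from compound 1 to compound 4 (0.08 log units; within the scatter), and the swap on the ring carbon gives a 1.3-fold higher number from compound 2 to compound 4 (0.12 log units; within the scatter). The six-membered ring alone therefore does not set compound 3 apart, since there is an at least 2.3-fold lower number from compound 3 to compound 4 (0.37 log units; beyond the scatter). The value of compound 3 remains a limit and not a number: the limit of > 100000 nM in this assay, at which 1 of the 4 values shown sits.

The compounds shown leave open whether the hydroxyl or its place on the ring separates compound 3 from the others, which a 2-methylpiperidin-1-yl or a 4-(2-hydroxyethyl)piperidin-1-yl group would help to decide. Going by these compounds, how a morpholin-4-yl group or a shorter chain would read in this assay also stays open.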